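A few compounds are considered here, and "the series" means these few. Any claim that something is new, unique, unknown or untested is made for them only; others in the source may bear on it.

Compound 1 `O=C(NO)c1ccc(NCc2nc(-c3ccc(Br)o3)nn2-c2ccccc2)cc1` gives 55.8% in an assay on Sf9 cells for inhibition of protein deacetylase HDAC6 (Homo sapiens), read by fluorescence, with a stated time of 40 min, tested at 100 nM; on this read-out higher numbers stand for more inhibition at the one concentration tested (going by the name of the read-out) and lower numbers for less inhibition. Compound 3 `O=C(NO)c1ccc(NCc2nc(-c3cc4ccccc4s3)nn2-c2ccccc2)cc1` gives 65.5%. Compound 2 `Nc1ccccc1NC(=O)c1ccc(NCc2nc(-c3ccccc3)nn2-c2ccccc2)cc1` gives 5%.

Compound 2 stands lowest of the three, with compound 1 beyond the scatter above it and compound 3 further still. Compound 4 `CNC(=O)c1ccc(NCc2nc(-c3ccccc3)nn2-c2ccccc2)cc1` differs from compound 2 in one place: methyl in place of 2-aminophenyl on an amide-type nitrogen. Among the compounds with values here, the only measured step, a number 9.7 percentage points higher from compound 1 to compound 3 (within the scatter), lies at the other end of the shared core and so says nothing about a change at the amide nitrogen. Within the data shown here, no measured step bears on this change. Since compound 2 already sits low at 5%, the step of a number 2 percentage points lower from compound 2 to compound 4 (within the scatter) is expected to stay within the scatter, with no real movement. Compound 4 is therefore estimated at 3%, in a range from -8% to 14%.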

Compound 4, a percentage reported as inhibition, at one concentration (the size of the read-out at that concentration, not a potency): -3.6%
Estimate against measurement, compound 4: 6.6 percentage points above; low and high end bracket the measured number.
By their numbers in this assay, from the lowest: compounds 4 and 2 (each within the scatter of the next); then compounds 1 and 3 (each within the scatter of the next).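

In this assay the first change read at this position, methyl in place of 2-aminophenyl on the amide-type nitrogen, gives a number 8.6 percentage points lower from compound 2 to compound 4 (within the scatter), so the read-out does not separate these two groups. Compound 2 gives only 5%, so any loss from this change would have little room to show. No evidence here bears on this result.

The compounds shown leave open how a plain phenyl or a longer alkyl chain on this nitrogen would read. From the compounds shown here alone, a carboxylic acid in place of the whole amide also remains open.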